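A few compounds are considered here, and "the series" means these few. Any claim that something is new, unique, unknown or untested is made for them only; others in the source may bear on it.

Of the compounds shown here, three built on one shared core have been measured. In an assay on HL-60 cells for agonist activity at vitamin D3 receptor (Homo sapiens), read by microscopy, with a stated time of 96 h (a lower number here means that less compound is needed, a higher number that more compound is needed for the effect), compound 1 `CCn1c(C(=O)NCCN(C)C)ccc1C(CC)(CC)c1ccc(OCC(O)C(C)(C)C)c(C)c1` gives 14 nM and compound 2 `CCn1c(C(=O)NCCN)ccc1C(CC)(CC)c1ccc(OCC(O)C(C)(C)C)c(C)c1` gives 10 nM, a step of a 1.4-fold lower number from compound 1 to compound 2 (0.15 log units; within the scatter). Compound 3 `C#CCCOC(=O)c1ccc(C(CC)(CC)c2ccc(OCC(O)C(C)(C)C)c(C)c2)n1CC` gives 1030 nM in this assay, the highest of the three numbers, and it stands nearest to compound 1 and furthest from compound 2. Compound 4 `CCOc1ccc(NC(=O)c2ccc(C(CC)(CC)c3ccc(OCC(O)C(C)(C)C)c(C)c3)n2CC)cc1` differs from compound 3 by (4-ethoxyphenyl)amino in place of (but-3-yn-1-yl)oxy on a carbonyl carbon, so that the ester of compound 3 becomes a carbamoyl group as in compounds 1 and 2. A large step downward is expected in this assay because the reverse moves a 74-fold higher number from compound 1 to compound 3 (1.87 log units; beyond the scatter) and a 100-fold higher number from compound 2 to compound 3 (2.01 log units; beyond the scatter) were both large. Compound 4 is therefore estimated at 60 nM, with a range of 10 nM to 350 nM. That estimate means an expected step of a 17-fold lower number from compound 3 to compound 4 (1.23 log units; beyond the scatter).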

Compound 4, half-maximal effective concentration: 630 nM
Compound 4: middle estimate off by 11-fold (1.02 log units), on the low side, and the stated range ends below it.
By their numbers in this assay, from the lowest: compounds 2 and 1 (each within the scatter of the next); then compounds 4 and 3 (each within the scatter of the next).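

In this assay, the amide link alone does not bring the low numbers of compounds 1 and 2: a 1.6-fold lower number from compound 3 to compound 4 (0.21 log units; within the scatter) leaves the ester and the (4-ethoxyphenyl)carbamoyl group level. The group on the amide-type nitrogen makes the difference instead, with a 63-fold higher number from compound 2 to compound 4 (1.80 log units; beyond the scatter) and a 45-fold higher number from compound 1 to compound 4 (1.65 log units; beyond the scatter) for 4-ethoxyphenyl against the two aminoalkyl chains. Going by these compounds, whether a 4-aminophenyl or a 2-hydroxyethyl group on that nitrogen would stand with compounds 1 and 2 or with compound 4 remains open. Nothing at hand explains these differences.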